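This account rests on a few compounds, and the source may have more. Where it says the series, first, only, none or still open, it means among the compounds named here.

Measured so far:
- compound 1, `C[C@H](CC(=O)NC(=N)NCCCc1c[nH]cn1)c1ccccc1`: in an in vitro functional assay on Sf9 cells for agonist activity at histamine H2 receptor (Cavia porcellus), read by GTPgammaS binding (a lower number here means that less compound is needed, a higher number that more compound is needed for the effect), compound 1 gives 75.9 nM
- compound 2, `Cc1nc(N)sc1CCCNC(=N)NC(=O)C[C@H](C)c1ccccc1`: in this assay compound 2 gives 7.76 nM

Going by the values given here, compound 2 stands lowest of the two numbers in this assay; the only neighbour is compound 1, whose number is higher by a margin beyond the usual scatter, so compound 2 needs less compound for the effect. The unmeasured compound 3, `C[C@@H](CC(=O)NC(=N)NCCCc1c[nH]cn1)c1ccccc1`, differs from compound 2 in one place: 1H-imidazol-4-yl in place of 2-amino-4-methyl-1,3-thiazol-5-yl on a saturated chain carbon, three bonds along the chain from an amine nitrogen. Among the compounds with values here, no measured pair shows this exact change on its own, so the size of the step can only be expected, not read off. Compound 1 also carries the 1H-imidazol-4-yl group on the same kind of chain, and in this assay compound 1 gives 75.9 nM, a number well above that of compound 2. On that basis the step from compound 2 to compound 3 is expected to go upward, with more compound needed, and a 7.7-fold higher number from compound 2 to compound 3 (0.89 log units; beyond the scatter) is the expected size. For compound 3 the estimated value in this assay is 60 nM, within a range from 15 nM to 250 nM.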

Compound 3, half-maximal effective concentration: 24 nM
The estimate for compound 3 lay 2.5-fold (0.40 log units) above the measured number; the measured number falls inside the stated range.
By their numbers in this assay, from the lowest: compound 2; then compound 3; then compound 1.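

In this assay, the exchange of 2-amino-4-methyl-1,3-thiazol-5-yl for 1H-imidazol-4-yl on a saturated chain carbon, three bonds along the chain from an amine nitrogen, can now be read on its own: the result is a 3.1-fold higher number from compound 2 to compound 3 (0.49 log units; beyond the scatter), so the change costs potency, but modestly. The result also shows that the drawn configuration at a saturated chain carbon counts in this test, since the same atoms and bonds, with that stereocentre drawn R in compound 1 and S in compound 3, give a 3.2-fold lower number from compound 1 to compound 3 (0.50 log units; beyond the scatter). That second comparison carries one limit on how cleanly it can be read: the fact that one of compounds 1 and 3 is drawn with a defined configuration and the other without, at the place where they differ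

The compounds shown leave open whether the R form of the 2-amino-4-methyl-1,3-thiazol-5-yl compound would sit above compound 2 by a similar step, so the effect of the stereocentre is known only with the 1H-imidazol-4-yl group. They also cannot say how much of the ring step belongs to the amine and how much to the methyl group on the ring, or how either ring would behave on a longer chain.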